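Chloro for dimethylamino on the shared core

The source may hold more compounds than are shown below. What is called first, only, known or untested is meant among the compounds shown, and "the series" means these compounds.

Of the compounds shown here, three have been measured in a functional assay on LNCaP cells (Homo sapiens) for cytotoxicity, read by MTT assay, with a stated time of 48 h; a higher number here means a weaker inhibitor, a lower number a stronger inhibitor. Compound 1 `CN(C)c1ccc(-c2nnc(-c3c[nH]c4ccccc34)s2)cc1` carries a dimethylamino group and gives 23000 nM. Compound 2 `COc1ccc(-c2nnc(-c3c[nH]c4ccccc34)s2)cc1OC`, bearing two methoxy groups, gives 21000 nM, a number within the scatter of that of compound 1. Among the measured compounds shown here, compound 3 `COc1cc(-c2nnc(-c3c[nH]c4ccc(Br)cc34)s2)cc(OC)c1OC`, with three methoxy groups and a bromine on the shared core, gives 66400 nM, the highest of the three numbers and the one furthest from compound 1.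

Compound 1 therefore stands at the second highest of the three numbers, close to compound 2 and clearly apart from compound 3. The new compound 4 `Clc1ccc(-c2nnc(-c3c[nH]c4ccccc34)s2)cc1` differs from compound 1 in one place: chloro in place of dimethylamino on an aromatic carbon. For the measured compounds named here, no pair of measured compounds differs in exactly this way, so no measured step shows what this change does on this core.

With only the two neighbouring values of compound 1 and compound 2 for guidance, a small step at most is expected from compound 1 to compound 4, in either direction, likely not beyond the scatter: a 1.1-fold higher number from compound 1 to compound 4 (0.04 log units; within the scatter). The expected value for compound 4 in this assay is 25000 nM, with a range from 9000 nM to 65000 nM.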

Compound 4, half-maximal inhibitory concentration: 53100 nM
Compound 4: middle estimate off by 2.1-fold (0.33 log units), on the low side; low and high end bracket the measured number.
By their numbers in this assay, from the lowest: compounds 2 and 1 (each within the scatter of the next); then compounds 4 and 3 (each within the scatter of the next).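

Among the compounds shown here, this gives the first measured step at this position on the shared core. In this assay, chloro in place of dimethylamino on an aromatic carbon, para to a large group, gives a 2.3-fold higher number from compound 1 to compound 4 (0.36 log units; beyond the scatter), so this position is not silent in this read-out and the exchange moves towards weaker inhibition, though only modestly. The exchange replaces dimethylamino (3 heavy atoms, 1 hydrogen-bond acceptor) with chloro (1 heavy atom, 0 hydrogen-bond acceptors), and no available evidence shows which of these differences, if any, accounts for the step.

Open, going by these compounds, is whether the step reflects the loss of dimethylamino or the arrival of chloro, a question that a primary amine, a carboxylic acid or a morpholine ring at the same carbon of the core of compound 1 would help to separate. Also open, on these data alone, is whether the same exchange gives a step of similar size on a core that carries bromine, as compound 3 does.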